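This account rests on a few compounds, and the source may have more. Where it says the series, first, only, none or still open, it means among the compounds named here.

Measured compounds in an assay on L cells for inhibition of Protein-serine O-palmitoleoyltransferase porcupine (Mus musculus), read by reporter gene assay, with a stated time of 24 h; a lower number here means that less compound is needed, a higher number that more compound is needed for the effect:

- compound 1, `CCOC(=O)c1ccc2nc(NC(=O)CNC(=O)c3nn(-c4ccccc4)c(=O)c4ccccc34)sc2c1`, gives > 25000 nM.
- compound 2, `O=C(CSc1nc2c(c(=O)n1-c1ccccc1)SCC2)Nc1ccc(-c2cncnc2)cn1`, gives 5.5 nM.
- compound 3, `O=C(CSc1nc2c(c(=O)n1-c1ccccc1)SCC2)Nc1ccc(-c2cccs2)cn1`, gives 0.3 nM.

The value of compound 1 is a limit of the assay and not a number, as shown by the limit of > 25000 nM in this assay, at which 1 of the 3 values shown sits; compound 1 therefore stands at the weak end of what was measured. Among the compounds with values here, compound 2 and compound 3 share a different core from compound 1, and the one measured step, an 18-fold lower number from compound 2 to compound 3 (1.26 log units; beyond the scatter), concerns that other core and does not bear on the change considered here.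

Compound 4, `O=C(CNC(=O)c1nn(-c2ccccc2)c(=O)c2ccccc12)Nc1nc2ccc(F)cc2s1`, differs from compound 1 by fluoro in place of ethoxycarbonyl on an aromatic carbon. Within the data shown here, no measured step on the core of compound 1 shows how this assay responds to a change on that ring. The only anchor is the limit of compound 1, so compound 4 is expected to remain weak, though with wide uncertainty: the estimate for compound 4 is 5000 nM, with a range from 100 nM to 25000 nM, which means an expected step of an at least 5.0-fold lower number from compound 1 to compound 4 (0.69 log units; beyond the scatter).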

Compound 4, half-maximal effective concentration: 470 nM
For compound 4 the middle estimate is 11-fold (1.03 log units) above the measured one, within the range that was stated.
By their numbers in this assay, from the lowest: compound 3; then compound 2; then compound 4. At a limit, above all of these: compound 1.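

On the shared core, this position on the six-membered aromatic ring of carbon only clearly matters in this assay: fluoro in place of ethoxycarbonyl brings an at least 53-fold lower number from compound 1 to compound 4 (1.72 log units; beyond the scatter). Compound 4 gives 470 nM, so this core can produce a measurable number once ethoxycarbonyl is gone. Compound 1 sits at a limit of the assay and not at a number, so the step gives only a minimum size: the limit of > 25000 nM in this assay, at which 1 of the 4 values shown sits.

As far as these compounds go, with only these two groups compared at this position, it remains open whether the change in the number comes from losing ethoxycarbonyl or from gaining fluoro; plain hydrogen, chloro, methoxy or a carboxylic acid there would help separate the two. Compound 4 also differs from compound 2 and compound 3 in more than one place, so these compounds do not show what this core could reach.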